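This account rests on a few compounds, and the source may have more. Where it says the series, first, only, none or still open, it means among the compounds named here.

Measured so far in a functional assay on L1210 cells (Mus musculus), with a stated time of 1 days; on this read-out lower numbers stand for lower potency and higher numbers for higher potency (the scale is a negative logarithm):
compound 1, `CC1=C(N2CC2)C(=O)C(C(C)COC(N)=O)=C(N2CC2)C1=O`, gives 5.31
compound 2, `CCC1=C(N2CC2)C(=O)C(CCOC(N)=O)=C(N2CC2)C1=O`, gives 4.88
compound 3, `CCC(COC(N)=O)C1=C(N2CC2)C(=O)C(C)=C(N2CC2)C1=O`, gives 5.2

Compound 2 holds the lowest of the three numbers; compound 3 is its nearest neighbour and compound 1 its furthest, both gaps beyond the scatter. Compound 1 and compound 2 are built from the same atoms joined differently; the difference between the two cores is not broken down here.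

Compound 3 arises from compound 1 by methyl in place of hydrogen on a saturated chain carbon, two bonds along the chain from a double-bonded ring carbon, and in this assay the step is a number 0.11 log units lower from compound 1 to compound 3 (within the scatter).

Compound 4, `CCCC1=C(N2CC2)C(=O)C(CCOC(N)=O)=C(N2CC2)C1=O`, remains to be measured. It arises from compound 2 by methyl in place of hydrogen on a saturated chain carbon, two bonds along the chain from a double-bonded ring carbon; the place reads the same word for word, so this is the same change as from compound 1 to compound 3, occurring twice among the compounds here. As far as these compounds go, on the core of compound 2 it is untested.

For compound 4 the expected step is a number 0.08 log units lower from compound 2 to compound 4 (within the scatter). Going by the values given here, this rests on the one earlier instance because a number 0.11 log units lower from compound 1 to compound 3 (within the scatter) is the only guide, and the different core widens the range. Compound 4 is thus estimated at 4.8 in this assay, between 4.4 and 5.2.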

Compound 4, logarithm of the reciprocal of the active concentration, log(1/C): 4.42
Estimate against measurement, compound 4: 0.38 log units above; the measured number falls inside the stated range.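

On the core of compound 2, in this assay, methyl in place of hydrogen on a saturated chain carbon, two bonds along the chain from a double-bonded ring carbon, gives a number 0.46 log units lower from compound 2 to compound 4 (beyond the scatter). Going by these compounds alone, only this step lies beyond the scatter, yet the comparison with the earlier instance does not separate the two cores: the same change on two cores in this assay, a number 0.11 log units lower (within the scatter) from compound 1 to compound 3 and a number 0.46 log units lower (beyond the scatter) from compound 2 to compound 4, 0.35 log units apart, within the scatter of two such steps. This supports carrying the change between these two cores as far as two instances allow, but it does not show that the step is identical on both, that it would hold on any further core, or why it takes the size it does.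

The compounds shown leave open what a longer chain such as butyl, or an amine, would give in the same place in this assay. Also open, as far as these compounds go, is whether the step persists when the carbamate side chain gives way to another group, such as a carboxylic acid.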